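Swapping the pyridin-2-yl for a dimethylcarbamoyl group

A few compounds are considered here, and "the series" means these few. Any claim that something is new, unique, unknown or untested is made for them only; others in the source may bear on it.

Within the data shown here, compound 3 `O=C(CCCCCCc1ccccc1)c1nc(-c2ccccn2)co1` gives 1.9 nM in an assay on isolated protein for inhibition of Fatty-acid amide hydrolase 1 (Rattus norvegicus) (a higher number here means a weaker inhibitor, a lower number a stronger inhibitor), the lowest of the three numbers so far, though compound 1 `CC(=O)c1coc(C(=O)CCCCCCc2ccccc2)n1` sits within the scatter of it at 2 nM, as the step of a 1.1-fold lower number from compound 1 to compound 3 (0.02 log units; within the scatter) shows. Compound 2 `O=C(CCCCCCc1ccccc1)c1nc(C(=O)C(F)(F)F)co1` stands far off at 470 nM; the step of a 240-fold higher number from compound 1 to compound 2 (2.37 log units; beyond the scatter) and the step of a 250-fold lower number from compound 2 to compound 3 (2.39 log units; beyond the scatter) are both large.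

Compound 4 `CN(C)C(=O)c1coc(C(=O)CCCCCCc2ccccc2)n1` has not yet been measured. It differs from compound 3 in one place: dimethylcarbamoyl in place of pyridin-2-yl on an aromatic carbon.

Two of the measured steps bear on this change. The step from compound 1 to compound 3 shows that a small carbonyl-bearing group and a pyridin-2-yl on that aromatic carbon give numbers within the scatter of each other, so the shared core tolerates groups of quite different shape there. The step from compound 1 to compound 2 shows that a change on the carbonyl carbon of that same group can cost a great deal. Among the measured compounds shown here, the dimethylcarbamoyl group keeps a carbonyl but carries a dimethylamino group on it, which no measured compound has, so its effect is uncertain. A moderate rise in the number is expected for compound 4, a 7.9-fold higher number from compound 3 to compound 4 (0.90 log units; beyond the scatter), with a wide range. The estimate for compound 4 is 15 nM, between 3 nM and 80 nM.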

Compound 4, inhibition constant: 35 nM
Estimate against measurement, compound 4: 2.3-fold (0.37 log units) below, within the range that was stated.
By their numbers in this assay, from the lowest: compounds 3 and 1 (each within the scatter of the next); then compound 4; then compound 2.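

Until now, this aromatic carbon had looked forgiving, since acetyl and pyridin-2-yl gave values within the scatter of each other, but in this assay dimethylcarbamoyl brings a clear loss, with an 18-fold higher number from compound 3 to compound 4 (1.27 log units; beyond the scatter) and, against the acetyl compound, an 18-fold higher number from compound 1 to compound 4 (1.24 log units; beyond the scatter). So the position does not accept every group alike, and keeping a carbonyl on that carbon is not enough to hold the low number of compound 1. The atoms on that carbonyl carbon now form a series of three, and a 13-fold lower number from compound 2 to compound 4 (1.13 log units; beyond the scatter) places the dimethylamino compound between the methyl and trifluoromethyl compounds, which shows a graded range of outcomes rather than a simple choice between a low number and a high one.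

Open, as far as these compounds go, is whether a methylamino or plain amino group on the same carbonyl carbon, a ring amine such as pyrrolidine there, or a methoxy group would stay nearer to methyl or to dimethylamino. Nothing shown here gives a measured reason for any of these differences.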